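Amide Aryl Variation in an Antiproliferative Series

This account rests on a few compounds, and the source may have more. Where it says the series, first, only, none or still open, it means among the compounds named here.

Measured compounds:
compound 1, `O=C(Nc1cccc(-c2oc3cc(-c4ccc(F)cc4)ccc3c(=O)c2O)c1)c1cccc(F)c1`, gives 5770 nM in a functional assay on MCF7 cells (Homo sapiens) for antiproliferative activity, read by CCK-8 assay, with a stated time of 72 h; on this read-out higher numbers stand for weaker inhibition and lower numbers for stronger inhibition
compound 2, `COc1cc(OC)cc(C(=O)Nc2cccc(-c3oc4cc(-c5ccc(F)cc5)ccc4c(=O)c3O)c2)c1`, gives 3470 nM in this assay

Of the compounds shown here, two have been measured so far, and they differ only in the aryl group attached to the amide carbonyl. For the measured compounds named here, the one step between them, a 1.7-fold lower number from compound 1 to compound 2 (0.22 log units; within the scatter), is small. Compound 2 therefore holds the lowest of the two numbers, with compound 1 the nearest to it, yet the gap between them does not exceed the usual scatter, so neither can be called the more potent.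

Compound 3, `N#Cc1ccc(C(=O)Nc2cccc(-c3oc4cc(-c5ccc(F)cc5)ccc4c(=O)c3O)c2)cc1`, has not been measured. It differs from compound 2 in one place: 4-cyanophenyl in place of 3,5-dimethoxyphenyl on a carbonyl carbon. Going by the values given here, the only measured step that bears on this change is the exchange of one aryl group for another at the same carbonyl carbon, and that step was within the scatter. On that basis a step of similar size is expected, with no direction established beyond the scatter. Compound 3 is thus expected to give about 4500 nM, ranging from 1500 nM to 13000 nM, a change of a 1.3-fold higher number from compound 2 to compound 3 (0.11 log units; within the scatter) that is estimated to stay close to compound 2.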

Compound 3, half-maximal inhibitory concentration: 2660 nM
For compound 3 the middle estimate is 1.7-fold (0.23 log units) above the measured one; the range from low to high includes it.
By their numbers in this assay, from the lowest: compounds 3, 2 and 1 (each within the scatter of the next, the first and the last beyond it).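

For the compounds shown here, at this carbonyl carbon, the exchange of 3-fluorophenyl for 4-cyanophenyl gives the first step beyond the scatter in this assay, namely a 2.2-fold lower number from compound 1 to compound 3 (0.34 log units; beyond the scatter), so the aryl group at this place can move the number, if only modestly. The exchange of 3,5-dimethoxyphenyl for 4-cyanophenyl, by contrast, gives a 1.3-fold lower number from compound 2 to compound 3 (0.12 log units; within the scatter), which leaves these two groups indistinguishable here even though they differ in heavy atoms and only 4-cyanophenyl has a triple bond. Compound 2 lies within the scatter of both compound 1 and compound 3, so the three aryl groups do not fall into clearly separated levels, and only the two ends of the series can be told apart. Nothing shown here offers an explanation for either step.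

The compounds shown leave open whether the nitrile itself matters or whether its place on the ring does, which 3-cyanophenyl or a 4-carboxyphenyl group at the same carbonyl carbon would begin to test. They also leave open whether an aromatic ring is needed at all, a question that a cyclohexyl or morpholine group there could address.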